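Working notes: from compound 3 to compound 4

This account rests on a few compounds, and the source may have more. Where it says the series, first, only, none or still open, it means among the compounds named here.

Measured in a functional assay on HepG2 cells (Homo sapiens) for antiproliferative activity, read by MTT assay, with a stated time of 48 h; on this read-out lower numbers stand for stronger inhibition and higher numbers for weaker inhibition:
- Compound 1 `CN1CCN(CC(=O)Nc2ccc3ncnc(Nc4cccc(C(F)(F)F)c4)c3c2)CC1`: > 100000 nM, a limit
- Compound 2 `CN1CCN(CC(=O)Nc2ccc3ncnc(Nc4cccc(Cl)c4)c3c2)CC1`: > 100000 nM, a limit
- Compound 3 `O=C(CN1CCCC1)Nc1ccc2ncnc(Nc3cccc(Br)c3)c2c1`: > 100000 nM, a limit

Compound 3 has no number, only its limit, and the whole series stands at the limit of > 100000 nM in this assay, at which 3 of the 3 values shown sit. Compound 4 `CN1CCN(CC(=O)Nc2ccc3ncnc(Nc4cccc(Br)c4)c3c2)CC1` differs from compound 3 as follows: 4-methylpiperazin-1-yl in place of pyrrolidin-1-yl on a saturated chain carbon bound to a carbonyl carbon. For the measured compounds named here, the only measured step, a step that the two limits leave unreadable from compound 1 to compound 2, lies at another place and gives no size. Compound 2 already carries 4-methylpiperazin-1-yl and gives > 100000 nM, again a limit. No readable step in either direction is therefore expected, and the estimated step is a number no higher from compound 3 to compound 4 (the limit leaves the size open). Compound 4 is expected at 100000 nM, with an estimated range of 40000 nM to 200000 nM.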

Compound 4, half-maximal inhibitory concentration: 25300 nM
Beside the measured number, compound 4's estimate is 4.0-fold (0.60 log units) above it; the whole stated range lies above it.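

In this assay, the change on the saturated chain carbon bound to a carbonyl carbon now has a size, with bromo held constant: an at least 3.9-fold lower number from compound 3 to compound 4 (0.59 log units; beyond the scatter). With 4-methylpiperazin-1-yl held constant, the aromatic carbon also matters, giving an at least 3.9-fold lower number from compound 2 to compound 4 (0.59 log units; beyond the scatter) and an at least 3.9-fold lower number from compound 1 to compound 4 (0.59 log units; beyond the scatter). Only the combination of bromo and 4-methylpiperazin-1-yl in compound 4 gives a measurable value, while the other compounds remain at the limit: the limit of > 100000 nM in this assay, at which 3 of the 4 values shown sit.

On these data alone, each step has only a lower bound, so its full size remains open. Also open, as far as these compounds go, is how morpholin-4-yl or dimethylamino at the chain carbon, or iodo on the aromatic carbon, would compare.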